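This account rests on a few compounds, and the source may have more. Where it says the series, first, only, none or still open, it means among the compounds named here.

Compound 3 `COC[C@H]1C[C@@](CC(C)C)(C(=O)O)N(C(=O)c2ccc(C(C)(C)C)c(OC)c2)[C@H]1C(N)=O` carries a carbamoyl group on a saturated ring carbon. In an ADME assay on Huh-5-2 cells (Homo sapiens) for cytotoxicity, with a stated time of 3 days (on this read-out higher numbers stand for lower toxicity in this test and lower numbers for higher toxicity in this test), compound 3 gives > 120000 nM, which is a limit of the assay rather than a number. Compound 2 `COC[C@H]1C[C@@](CC(C)C)(C(=O)O)N(C(=O)c2ccc(C(C)(C)C)c(OC)c2)[C@H]1[C@H]1COC(=O)O1` also reaches only a limit, giving > 120000 nM in this assay. Compound 1 `COC[C@H]1C[C@@](CC(C)C)(C(=O)O)N(C(=O)c2ccc(C(C)(C)C)c(OC)c2)[C@@H]1c1nccs1` gives 200000 nM in this assay. Among the measured compounds shown here, the single step between measured neighbours, a step that the two limits leave unreadable from compound 2 to compound 3, cannot be sized because of the limit of > 120000 nM in this assay, at which 2 of the 3 values shown sit. Compound 4 `CC[C@H]1[C@@H](COC)C[C@@](CC(C)C)(C(=O)O)N1C(=O)c1ccc(C(C)(C)C)c(OC)c1` differs from compound 3 by ethyl in place of carbamoyl on a saturated ring carbon. For the measured compounds named here, no measured step resembles this change, and all values shown sit high on this read-out, so no shift beyond the scatter is expected, and the assay will most likely again report only a limit. Compound 4 is therefore expected near 150000 nM, between 80000 nM and 300000 nM, an expected step that the limit leaves unreadable from compound 3 to compound 4.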

Compound 4, half-maximal cytotoxic concentration: 200000 nM
Compound 4: the middle estimate sits 1.3-fold (0.12 log units) below what was measured; the range from low to high includes it.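

No new step can be read from compound 4 to compound 3 or compound 2, because each comparison rests on a limit and not on a number: the limit of > 120000 nM in this assay, at which 2 of the 4 values shown sit. The compounds shown leave open whether changing the group on this saturated ring carbon shifts the result in this assay at all.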